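This account rests on a few compounds, and the source may have more. Where it says the series, first, only, none or still open, it means among the compounds named here.

Of the compounds shown here, three have been measured in an assay for positive allosteric modulation of metabotropic glutamate receptor 3 (Rattus norvegicus); on this read-out higher numbers stand for an effect only at larger amounts of compound and lower numbers for an effect already at smaller amounts. Among the measured compounds shown here, compound 1 `Cc1ncc(OCCCCOc2ccc(C(=O)CC(C)(C)C)c(O)c2C)cc1C(=O)O` gives 79 nM, and compound 2 `Cc1ccc(OCCCCOc2ccc(C(=O)CC(C)(C)C)c(O)c2C)cc1C(=O)O` gives 309 nM; the one change between them produced a 3.9-fold higher number from compound 1 to compound 2 (0.59 log units; beyond the scatter). Compound 3 `Cc1c(OC[C@@H](C)COc2cc(C(=O)O)ccc2F)ccc(C(=O)CC(C)(C)C)c1O` gives 3950 nM, the highest of the three numbers, so that among the measured compounds it needs the largest amount to act.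

Compound 4 `COc1ccccc1OC[C@H](C)COc1ccc(C(=O)CC(C)(C)C)c(O)c1C` has not yet been measured. It differs from compound 3 in one place: 2-methoxyphenyl in place of 5-carboxy-2-fluorophenyl on an oxygen on a saturated carbon. The measured step from compound 1 to compound 2 swapped one carboxy-bearing ring for another carboxy-bearing ring, so it says little about a change in which the carboxylic acid disappears altogether and a methoxy group arrives. For the measured compounds named here, no measured pair shows what that kind of change does in this assay, and the expectation must therefore be loose. Compound 4 is expected to give 6000 nM, within a wide range from 1500 nM to 25000 nM. That corresponds to an expected step of a 1.5-fold higher number from compound 3 to compound 4 (0.18 log units; within the scatter), meaning no confident change beyond the scatter is forecast.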

Compound 4, half-maximal effective concentration: "not active" (no number reported)
The entry for compound 4 holds no number, and the estimate cannot be compared.
By their numbers in this assay, from the lowest: compound 1; then compound 2; then compound 3.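

Among the compounds shown here, compound 4 is reported as not active in this assay, without a number, so no step from compound 3 to compound 4 can be read. The compounds shown leave open whether losing the carboxy group or gaining the methoxy group decides this outcome. No evidence here bears on the result.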